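Half-life notes: aryl ester variation on the phosphate prodrug

The source may hold more compounds than are shown below. What is called first, only, known or untested is meant among the compounds shown, and "the series" means these compounds.

Two compounds of this series have numbers in an ADME assay on blood (Homo sapiens) for pharmacokinetics; a higher number here means that the compound lasts longer, a lower number that the compound disappears faster. Compound 1 `COC(=O)CCNC(=O)[C@@H]1O[P@](=O)(OCOC(=O)c2ocnc2C)OCC1(C)C` gives 0.27 h in this assay. Compound 2 `COC(=O)CCNC(=O)[C@@H]1O[P@](=O)(OCOC(=O)c2scnc2C(C)(C)C)OCC1(C)C` gives 0.44 h in this assay. Going by the values given here, the only step measured so far, a 1.6-fold higher number from compound 1 to compound 2 (0.21 log units; within the scatter), exchanges one five-membered aromatic ring with 2 hetero atoms for another on a carbonyl carbon; the two values lie within the scatter of each other, so compound 2 and compound 1 cannot be told apart on this assay.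

Compound 3 `COC(=O)CCNC(=O)[C@@H]1O[P@](=O)(OCOC(=O)c2cc(C)nn2C)OCC1(C)C` is not yet measured. Relative to compound 2 the change is 1,3-dimethyl-1H-pyrazol-5-yl in place of 4-(tert-butyl)-1,3-thiazol-5-yl on a carbonyl carbon; the new group is again a five-membered aromatic ring with 2 hetero atoms, 0 hydrogen-bond donors and 2 hydrogen-bond acceptors, on the same carbonyl carbon. Among the compounds with values here, the only step that bears on it is the one from compound 1 to compound 2, which stayed within the scatter. A step no larger than the scatter is therefore expected from compound 2 to compound 3, a 1.3-fold lower number from compound 2 to compound 3 (0.10 log units; within the scatter), with no direction claimed. Compound 3 is expected to give about 0.35 h in this assay, within a range of 0.15 h to 0.8 h.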

Compound 3, half-life: < 0.16 h
Compound 3 ended at the assay's limit (the forecaster's own chance of this, stated with the estimate: 5%); middle value at least 2.1-fold (0.33 log units) from the limit.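

In this assay, the group on this carbonyl carbon can now be seen to matter: the series shows an at least 2.7-fold lower number from compound 2 to compound 3 (0.43 log units; beyond the scatter), its first step beyond the scatter, with 1,3-dimethyl-1H-pyrazol-5-yl replacing 4-(tert-butyl)-1,3-thiazol-5-yl. The second new reading is less firm, an at least 1.6-fold lower number from compound 1 to compound 3 (0.22 log units; that floor lies within the scatter), so 1,3-dimethyl-1H-pyrazol-5-yl and 4-methyl-1,3-oxazol-5-yl cannot be separated on this result, even though all three groups are five-membered aromatic rings with 2 hetero atoms. For compound 3, the value < 0.16 h is a limit of the assay and not a number, and both new steps therefore give only a floor: the limit of < 0.16 h in this assay, at which 1 of the 3 values shown sits.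

Going by these compounds, how far compound 3 actually lies from compound 2 stays open, and each step changes the ring hetero atoms and the ring substituents together, so the contribution of either one alone cannot be read. Also open, on these data alone, is how this assay would respond to a non-aromatic group on this carbonyl carbon, such as a plain alkyl chain, or to an amine on the five-membered ring.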